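A few compounds are considered here, and "the series" means these few. Any claim that something is new, unique, unknown or untested is made for them only; others in the source may bear on it.

Measured so far:
- compound 1 `C[C@H]1O[C@H](CO)[C@@H](O)[C@H](O)[C@H]1O`: 50100000 nM
- compound 2 `[N-]=[N+]=NC[C@H]1O[C@H](CO)[C@@H](O)[C@H](O)[C@H]1O`: 25100000 nM
- compound 3 `CNNC(=O)[C@H]1O[C@H](CO)[C@@H](O)[C@H](O)[C@H]1O`: 2000000 nM

All three share a sugar-like core and were tested in an assay on isolated protein (Sus scrofa) for inhibition of glycogen phosphorylase, brain form (Homo sapiens); on this read-out higher numbers stand for weaker inhibition and lower numbers for stronger inhibition. Compound 3 gives the lowest number of the three: compared with compound 2 the step is a 13-fold lower number from compound 2 to compound 3 (1.10 log units; beyond the scatter), and compared with compound 1 it is a 25-fold lower number from compound 1 to compound 3 (1.40 log units; beyond the scatter), both beyond the scatter. The step of a 2.0-fold lower number from compound 1 to compound 2 (0.30 log units; within the scatter), by contrast, lies within the scatter.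

Compound 4 `O=C(O)[C@H]1O[C@H](CO)[C@@H](O)[C@H](O)[C@H]1O` differs from compound 3 in one place: hydroxy in place of (methylamino)amino on a carbonyl carbon. For the measured compounds named here, no measured pair shows this particular exchange, so no step bears on it directly. The two steps that end at compound 3 only show that placing the (methylamino)carbamoyl group on the ring carbon lowered the number sharply; they say nothing about what happens when the (methylamino)amino part is taken away and a hydroxy put in its place. The outcome is therefore uncertain. Compound 4 is expected to give a higher number than compound 3, that is a weaker inhibition, with an estimated step of a 4.0-fold higher number from compound 3 to compound 4 (0.60 log units; beyond the scatter). The estimate for compound 4 in this assay is 8000000 nM, within a range from 2000000 nM to 30000000 nM.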

Compound 4, inhibition constant: 15800000 nM
Compound 4: middle estimate off by 2.0-fold (0.30 log units), on the low side, and the stated range covers the measured number.
By their numbers in this assay, from the lowest: compound 3; then compounds 4, 2 and 1 (each within the scatter of the next, the first and the last beyond it).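

In this assay the swap of (methylamino)amino for hydroxy on the carbonyl carbon gives a 7.9-fold higher number from compound 3 to compound 4 (0.90 log units; beyond the scatter) and so shows that the low number of compound 3 depends on more than a carbonyl at this ring carbon, since the group attached to that carbonyl also counts. A carboxy group in place of methyl still gives a 3.2-fold lower number from compound 1 to compound 4 (0.50 log units; beyond the scatter) as a modest change, yet carboxy in place of azidomethyl gives a 1.6-fold lower number from compound 2 to compound 4 (0.20 log units; within the scatter) and stays within the scatter, so carboxy cannot be told apart from azidomethyl here. Nothing available explains these differences.

Going by these compounds, it remains open whether the methyl of the (methylamino)amino part matters, which a plain hydrazide would test. A simple amide or a methyl ester on the same carbonyl carbon would show whether the nitrogen next to the carbonyl is enough.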